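The source may report more compounds than this note shows. Statements on the series, on what has been measured and on what is new or still open speak of the compounds shown alone.

Of the compounds shown here, two have been measured so far in an ADME assay on BJ cells (Homo sapiens) for cytotoxicity, read by CellTiter-Glo and resazurin assay, with a stated time of 72 h (on this read-out higher numbers stand for an effect only at larger amounts of compound and lower numbers for an effect already at smaller amounts), and neither gives a number. Compound 2 (`CCOC(=O)CCCCCOc1cccc(CN(C(=O)c2ccc(-c3ccc4c(c3)OCCO4)cc2)C(C)C)c1`) reads > 24400 nM, which is a limit of the assay and not a number. Compound 1 (`CC(C)N(Cc1cccc(OCCCCCC(=O)O)c1)C(=O)c1ccc(-c2cccc(F)c2)cc1`) reads > 26000 nM, and this too is a limit. For the measured compounds named here, compound 2 therefore has no exact position on the scale, and the only other value available offers no exact figure to compare it with.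

Compound 3 (`CCOC(=O)CCCCCOc1cccc(CN(C(=O)c2ccc(-c3cccc(F)c3)cc2)C(C)C)c1`) follows from compound 2 through one change: 3-fluorophenyl in place of 2,3-dihydro-1,4-benzodioxin-6-yl on an aromatic carbon, para to a large group (3-fluorophenyl in place of 2,3-dihydro-1,4-benzodioxin-6-yl on an aromatic carbon). Going by the values given here, no measured step shows what this exchange does. In this assay, no step beyond the usual scatter is expected, and this expectation rests only on compound 2 with its reading of > 24400 nM. Compound 3 will most likely also be reported as a limit.

If a number is obtained, compound 3 is estimated at 25000 nM, with an expected range from 11000 nM to 50000 nM. This estimate means an expected step that the limit leaves unreadable from compound 2 to compound 3.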

Compound 3, half-maximal effective concentration: > 26000 nM
Compound 3: no number, only a limit (the forecaster's own chance of this, stated with the estimate: 75%); middle value at least 1.0-fold (0.01 log units) from the limit.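

With compound 3 also reported only as a limit, the steps from compound 2 to compound 3 and from compound 1 to compound 3 cannot be read in this assay. The compounds shown leave open where any of the three would give an actual number, and whether either exchange changes the reading at all.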